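Trimming one ester chain of compound 2 to methyl

The source may report more compounds than this note shows. Statements on the series, on what has been measured and on what is new or still open speak of the compounds shown alone.

Measured compounds:
- compound 1 `CSc1ncc(C2C(C(=O)OCC(C)C)=C(C)NC(C)=C2C(=O)OCC(C)C)n1Nc1ccccc1`: 6.71 nM
- compound 2 `COCCOC(=O)C1=C(C)NC(C)=C(C(=O)OCCOC)C1c1cnc(SC)n1Nc1ccccc1`: 17.9 nM
- compound 3 `CSc1ncc(C2C(C(=O)OCCCc3ccccc3)=C(C)NC(C)=C2C(=O)OCCCc2ccccc2)n1Nc1ccccc1`: 3.15 nM

In an assay on isolated protein (strain albino) for antagonist activity at Voltage-dependent L-type calcium channel subunit alpha-1C (Cavia porcellus) (a higher number here means a weaker inhibitor, a lower number a stronger inhibitor), compound 2 gives the highest of the three numbers, and its gaps to compound 1 and to compound 3 both lie beyond the usual scatter. All three share one core and differ only in the chains attached to the oxygen next to each carbonyl group; compound 1 carries isobutyl there and compound 3 carries 3-phenylpropyl, and both give lower numbers than the 2-methoxyethyl chains of compound 2.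

Compound 4 `COCCOC(=O)C1=C(C)NC(C)=C(C(=O)OC)C1c1cnc(SC)n1Nc1ccccc1` has not yet been measured. It differs from compound 2 at one of these two chains: hydrogen in place of methoxymethyl on a saturated chain carbon bound to an oxygen next to a carbonyl group. Among the compounds with values here, no measured pair shows this exact change, so its size must be guessed from the spread of the three numbers. The step from compound 2 to compound 4 is expected to be small, toward a somewhat higher number or none beyond the scatter, as a 1.4-fold higher number from compound 2 to compound 4 (0.15 log units; within the scatter) states. Compound 4 is therefore expected to give about 25 nM, within a range from 8 nM to 80 nM.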

Compound 4, half-maximal inhibitory concentration: 9.65 nM
Beside the measured number, compound 4's estimate is 2.6-fold (0.41 log units) above it; the measured number falls inside the stated range.
By their numbers in this assay, from the lowest: compound 3; then compounds 1, 4 and 2 (each within the scatter of the next, the first and the last beyond it).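

Compounds 1, 2 and 3 differ from one another at both ester chains, so they could not show what a single chain contributes. In this assay, within the data shown here, replacing just one 2-methoxyethyl chain with methyl gives a 1.9-fold lower number from compound 2 to compound 4 (0.27 log units; within the scatter) and this is the first view of one chain alone: losing methoxymethyl, with its three heavy atoms and one hydrogen-bond acceptor, produces no change that can be told from the scatter at this position. Nothing available here explains this result.

As far as these compounds go, it remains open whether methyl at both ester positions would keep the number in this range, or whether the second 2-methoxyethyl chain matters more. Also open, from the compounds shown here alone, is how a carboxylic acid in place of this ester, or a longer chain ending in an amine, would behave.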